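Notes on a carbonyl substituent swap

This account rests on a few compounds, and the source may have more. Where it says the series, first, only, none or still open, it means among the compounds named here.

In a functional assay on HCT-116 cells (Homo sapiens) for antiproliferative activity (a higher number here means a weaker inhibitor, a lower number a stronger inhibitor), compound 1 `COCCC(=O)N1CCCc2c(C)c3c(n2-c2ccc(C(N)=O)c(c2)N[C@@H](C)[C@@H]1C)CC(C)(C)CC3=O` gives 55 nM and compound 2 `COCCC(=O)N1CCc2c(C)c3c(n2-c2ccc(C(N)=O)c(c2)N[C@@H](C)[C@H](C)C1)CC(C)(C)CC3=O` gives 38 nM, so these two stand within the scatter of each other. Compound 3 `Cc1c2c(n3c1CCN(C(=O)C1(N)CCCC1)C[C@@H](C)[C@H](C)Nc1cc-3ccc1C(N)=O)CC(C)(C)CC2=O` keeps the core of compound 2 and carries 1-aminocyclopentyl in place of 2-methoxyethyl on a carbonyl carbon. Going by the values given here, no measured pair tests this change, so nothing beyond the scatter is expected in either direction. The expected step of a 1.1-fold higher number from compound 2 to compound 3 (0.02 log units; within the scatter) is therefore small. For compound 3 the estimated value is 40 nM, with an expected range of 12 nM to 130 nM.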

Compound 3, half-maximal inhibitory concentration: 27 nM
For compound 3 the middle estimate is 1.5-fold (0.17 log units) above the measured one; the measured number falls inside the stated range.
By their numbers in this assay, from the lowest: compounds 3, 2 and 1 (each within the scatter of the next, the first and the last beyond it).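

Going by these compounds alone, on a carbonyl carbon, 1-aminocyclopentyl in place of 2-methoxyethyl gives a 1.4-fold lower number from compound 2 to compound 3 (0.15 log units; within the scatter) in this assay, the first reading of a change at this position. This position therefore takes a five-membered ring and a hydrogen-bond donor with no shift beyond the scatter. No available evidence bears on this result. The compounds shown leave open whether the amine matters, since plain cyclopentyl is not among them. Going by these compounds, a carboxylic acid on the same ring or a longer chain in place of 2-methoxyethyl also remains open.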